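The source may hold more compounds than are shown below. What is called first, only, known or untested is meant among the compounds shown, and "the series" means these compounds.

Working notes on the series.

Compound 1 `Nc1cccc(-c2cn3nc(-c4cccs4)sc3n2)c1` gives in a functional assay on HeLa cells (Homo sapiens) for inhibition, read by cell counting, with a stated time of 4 days (a higher number here means a weaker inhibitor, a lower number a stronger inhibitor), only a limit, > 250000 nM; this is the limit of > 250000 nM in this assay, at which 1 of the 2 values shown sits. Within the data shown here, compound 2 `C=C(Br)C(=O)Nc1cccc(-c2cn3nc(-c4ccc(CC)cc4)sc3n2)c1` gives 3200 nM, the single measured number. Compound 3 `C=C(Br)C(=O)Nc1cccc(-c2cn3nc(Cc4ccc(Cl)cc4)sc3n2)c1` differs from compound 2 by 4-chlorobenzyl in place of 4-ethylphenyl on an aromatic carbon. Among the measured compounds shown here, no measured pair shows such a change, so the size of the step rests on expectation alone; a modest loss of potency, a 1.9-fold higher number from compound 2 to compound 3 (0.27 log units; within the scatter), is expected. Compound 3 is estimated at 6000 nM, with a range from 1500 nM to 25000 nM.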

Compound 3, half-maximal inhibitory concentration: 2700 nM
For compound 3 the middle estimate is 2.2-fold (0.35 log units) above the measured one; the measured number falls inside the stated range.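

At this position, on an aromatic carbon next to the ring nitrogen and next to the ring sulfur, 4-chlorobenzyl in place of 4-ethylphenyl gives in this assay a 1.2-fold lower number from compound 2 to compound 3 (0.07 log units; within the scatter). The two groups, each with one six-membered aromatic ring and 8 heavy atoms, are therefore not told apart in this assay. Nothing measured here bears on this step.

Still open, going by these compounds, is whether a much smaller group at this position, such as methyl, gives a similar value. On these data alone, it is also open whether a benzyl group carrying an amine or a carboxylic acid does so.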